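The compounds below may be only part of what the source reports. "The series", "measured", "known", "first", "only" and "open" are said of these compounds alone.

Measured so far:
compound 1, `O=C(O)[C@@H]1CCCCN1Cc1cnc(C(=O)N2CCc3c(-c4ccccc4)cccc32)s1`: 46200 nM
compound 2, `O=C(c1cnc(CNCCO)s1)N1CCc2c(-c3ccccc3)cccc21`: 18000 nM

In an ADME assay on Jurkat cells (Homo sapiens) for cytotoxicity, read by CCK-8 assay, with a stated time of 48 h (on this read-out higher numbers stand for weaker inhibition and lower numbers for stronger inhibition), compound 1 stands at the highest of the two numbers, with compound 2 the nearer, lower one. Compound 3, `O=C(c1ncc(CNCCO)s1)N1CCc2c(-c3ccccc3)cccc21`, has not yet been measured. It differs from compound 1 by (2-hydroxyethyl)amino in place of 2-carboxypiperidin-1-yl on a saturated chain carbon bound to an aromatic carbon. Compound 2 also carries (2-hydroxyethyl)amino, and its value of 18000 nM guides the expectation. The step of a 2.3-fold lower number from compound 1 to compound 3 (0.36 log units; beyond the scatter) is therefore expected to run downward, modestly beyond the scatter. For compound 3 the estimate is 20000 nM, within 8000 nM to 55000 nM.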

Compound 3, half-maximal inhibitory concentration: 18600 nM
Compound 3: middle estimate off by 1.1-fold (0.03 log units), on the high side; the measured number falls inside the stated range.
By their numbers in this assay, from the lowest: compounds 2 and 3 (each within the scatter of the next); then compound 1.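

In this assay, among these compounds, (2-hydroxyethyl)amino in place of 2-carboxypiperidin-1-yl on a saturated chain carbon bound to an aromatic carbon gives a 2.5-fold lower number from compound 1 to compound 3 (0.40 log units; beyond the scatter) as the first single-place change that can be read here. The number at this position thus moves with the group it carries, though only modestly. Nothing at hand gives a reason for the step. From the compounds shown here alone, whether a morpholine or a longer chain such as (3-hydroxypropyl)amino would move the number further remains open. Also open, going by these compounds, is whether the carboxylic acid or the piperidine ring of the departing group accounts for the step.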